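Antagonist series: methoxy replacing chloro on compound 2

The source may hold more compounds than are shown below. What is called first, only, known or untested is meant among the compounds shown, and "the series" means these compounds.

Values in a functional assay on cells for antagonist activity at Free fatty acid receptor 1 (Homo sapiens), read by TR-FRET and inositol phosphate accumulation, with a stated time of 2 h; on this read-out higher numbers stand for weaker inhibition and lower numbers for stronger inhibition:
compound 1, `Cc1cc(COc2ccccc2)nc(-c2ccccn2)n1`, gives 794 nM
compound 2, `Cc1cc(COc2ccccc2Cl)nc(-c2ccccn2)n1`, gives 316 nM
compound 3, `Cc1cc(COc2ccc(Cl)cc2)nc(-c2ccccn2)n1`, gives 251 nM

Compound 2 stands second highest of the three numbers. The nearest number belongs to compound 3, the furthest to compound 1. In steps: a 2.5-fold lower number from compound 1 to compound 2 (0.40 log units; beyond the scatter); a 1.3-fold lower number from compound 2 to compound 3 (0.10 log units; within the scatter). The first of these lies beyond the scatter, the second within it.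

Compound 4, `COc1ccccc1OCc1cc(C)nc(-c2ccccn2)n1`, is not yet measured. It differs from compound 2 in one place: methoxy in place of chloro on an aromatic carbon of a six-membered aromatic ring of carbon only, ortho to a large group. Among the compounds with values here, two measured steps bear on this. The step of a 2.5-fold lower number from compound 1 to compound 2 (0.40 log units; beyond the scatter) shows what chloro at this place gave over hydrogen; the step of a 1.3-fold lower number from compound 2 to compound 3 (0.10 log units; within the scatter) shows that shifting the chloro around the ring leaves the number within the scatter. Within the data shown here, no measured pair sets methoxy against chloro, so the size of that exchange is not known from these compounds. The expectation is that methoxy keeps part of the gain seen with chloro, so that in this assay the step of a 1.4-fold higher number from compound 2 to compound 4 (0.15 log units; within the scatter) is expected to stay close to the scatter, if anything toward a higher number. Compound 4 is estimated at 450 nM, with a range from 200 nM to 1100 nM.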

Compound 4, half-maximal inhibitory concentration: 2000 nM
The estimate for compound 4 lay 4.4-fold (0.65 log units) below the measured number, outside the stated range (above it).
By their numbers in this assay, from the lowest: compounds 3 and 2 (each within the scatter of the next); then compound 1; then compound 4.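

In this assay the place ortho to a large group proves sensitive to which group it carries: methoxy in place of chloro gives a 6.3-fold higher number from compound 2 to compound 4 (0.80 log units; beyond the scatter) and so loses all of the gain that chloro brought. Set against hydrogen, methoxy goes the other way, with a 2.5-fold higher number from compound 1 to compound 4 (0.40 log units; beyond the scatter) as against a 2.5-fold lower number from compound 1 to compound 2 (0.40 log units; beyond the scatter) for chloro, so a group at this place can move the number in either direction and the earlier compounds showed only the lowering. Nothing measured here accounts for the opposite directions of chloro and methoxy at this place.

The compounds shown leave open whether methoxy would also raise the number at the ring place that carries chloro in compound 3, where chloro and the place held in compound 2 could not be told apart in this assay. They also leave open how a methyl, a fluoro or an ethoxy would sit between hydrogen, chloro and methoxy at this place, which would show whether the methoxy result stands alone or belongs to a wider trend.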